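A Dimethoxy Swap on a Weakly Active Series

The source may report more compounds than this note shows. Statements on the series, on what has been measured and on what is new or still open speak of the compounds shown alone.

In a functional assay on OVCAR-3 cells (Homo sapiens) for antiproliferative activity, read by spectrophotometry, with a stated time of 2 days (on this read-out lower numbers stand for stronger inhibition of growth and higher numbers for weaker inhibition of growth), compound 1 (`Cc1ccc(Nc2ncc(C(F)(F)F)c(N3Cc4cccc(N(C)S(C)(=O)=O)c4C3)n2)cc1C`) gives > 30000 nM as a limit of the assay, not as a number. Compound 1 thus stands at the limit of > 30000 nM in this assay, at which 2 of the 3 values shown sit, without a number of its own. Compound 3 (`CN(c1cccc2c1CN(c1nc(Nc3cc(C(F)(F)F)cc(C(F)(F)F)c3)ncc1C(F)(F)F)C2)S(C)(=O)=O`) gives > 30000 nM as a limit too. Compound 2 (`CN(c1cccc2c1CN(c1nc(Nc3cccc(Oc4ccccc4)c3)ncc1C(F)(F)F)C2)S(C)(=O)=O`) gives 24900 nM as a true number.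

The next compound to be tested is compound 4 (`COc1cc(Nc2ncc(C(F)(F)F)c(N3Cc4cccc(N(C)S(C)(=O)=O)c4C3)n2)cc(OC)c1`), which keeps the core of compound 1. It carries 3,5-dimethoxyphenyl in place of 3,4-dimethylphenyl on a nitrogen on an aromatic ring. The counted difference reads as follows: 3,5-dimethoxyphenyl in place of 3,4-dimethylphenyl on a nitrogen on an aromatic ring (the change in full).

In this assay the estimated step of an at least 1.0-fold lower number from compound 1 to compound 4 (0.02 log units; that floor lies within the scatter) is expected to stay within the usual scatter, with no direction that can be named in advance. Within the data shown here, this expectation rests on compound 2, whose reading of 24900 nM is the only number so far and still marks weak inhibition of growth. Compound 4 may well come out only as a limit again. If a number is obtained, compound 4 is expected at 28000 nM with an estimated range from 12000 nM to 50000 nM around it.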

Compound 4, concentration for 50% growth inhibition: 630 nM
For compound 4 the middle estimate is 44-fold (1.65 log units) above the measured one, and the stated range ends above it.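

In this assay, replacing 3,4-dimethylphenyl with 3,5-dimethoxyphenyl on a nitrogen on an aromatic ring gives an at least 47-fold lower number from compound 1 to compound 4 (1.67 log units; beyond the scatter), which shows that the group at this place alone can move the read-out by a large margin while the core of compound 1 stays the same. Among the other compounds, only compound 2 gives a true number, 24900 nM, which marks weak inhibition of growth, whereas compound 4 at 630 nM is the first reading to show that this series can reach a much lower number. Compound 1 and compound 3 remain at a limit of the assay rather than a number: the limit of > 30000 nM in this assay, at which 2 of the 4 values shown sit.

The compounds shown do not separate the contribution of the methoxy groups from that of their arrangement, a question that 3,5-dimethylphenyl and 3,4-dimethoxyphenyl at the same place would address. They also leave open whether the result depends on the ether oxygens themselves, as 3,5-dihydroxyphenyl or 3,5-diethoxyphenyl would test, and whether a single methoxy group, as in 3-methoxyphenyl, would be enough.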